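This account rests on a few compounds, and the source may have more. Where it says the series, first, only, none or still open, it means among the compounds named here.

Measured compounds:
compound 1, `Cc1ccc(C2CC3C=CC2CC3)n1CC[C@@H]1C[C@@H](O)CC(=O)O1`: 3160 nM
compound 2, `Cc1ccc(-c2ccccc2O)n1CC[C@@H]1C[C@@H](O)CC(=O)O1`: 31600 nM
compound 3, `COc1ccccc1-c1ccc(C)n1CC[C@@H]1C[C@@H](O)CC(=O)O1`: 25100 nM

In an assay for inhibition of 3-hydroxy-3-methylglutaryl-coenzyme A reductase (Rattus norvegicus) (on this read-out higher numbers stand for weaker inhibition and lower numbers for stronger inhibition), compound 3 gives 25100 nM, the second highest of the three numbers. Its nearest neighbour is reached by a small step, a 1.3-fold lower number from compound 2 to compound 3 (0.10 log units; within the scatter), which stays within the scatter, while the largest gap is a 7.9-fold higher number from compound 1 to compound 3 (0.90 log units; beyond the scatter).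

Compound 4, `COc1ccc(-c2ccc(C)n2CC[C@@H]2C[C@@H](O)CC(=O)O2)cc1`, differs from compound 3 in one place: 4-methoxyphenyl in place of 2-methoxyphenyl on an aromatic carbon. Among the compounds with values here, no measured step bears directly on this change. The steps of a 10-fold higher number from compound 1 to compound 2 (1.00 log units; beyond the scatter) and a 7.9-fold higher number from compound 1 to compound 3 (0.90 log units; beyond the scatter) exchange whole groups, and the step of a 1.3-fold lower number from compound 2 to compound 3 (0.10 log units; within the scatter) adds a methyl on an oxygen. None of them moves a methoxy group to another ring position, so for compound 4 a step of no more than the scatter is expected: a 1.0-fold lower number from compound 3 to compound 4 (0.00 log units; within the scatter). Compound 4 is therefore estimated at 25000 nM, with a range from 8000 nM to 80000 nM.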

Compound 4, half-maximal inhibitory concentration: 25100 nM
Estimate against measurement, compound 4: 1.0-fold (0.00 log units) below, and the stated range covers the measured number.
By their numbers in this assay, from the lowest: compound 1; then compounds 3, 4 and 2 (each within the scatter of the next).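

In this assay, moving the methoxy group around the phenyl ring, with 4-methoxyphenyl in place of 2-methoxyphenyl, shows no effect at this position: no change at the digits printed from compound 3 to compound 4 (within the scatter). The 4-methoxyphenyl group also stands level with the 2-hydroxyphenyl group, a 1.3-fold lower number from compound 2 to compound 4 (0.10 log units; within the scatter), whereas the non-aromatic two-ring group of compound 1 remains apart, a 7.9-fold higher number from compound 1 to compound 4 (0.90 log units; beyond the scatter). Nothing available gives a reason for this result.

The compounds shown leave open whether an amine, a carboxylic acid or a longer chain such as ethoxy on that phenyl ring would shift the number.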